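Urea in place of amide: a step expected to change little

The source may report more compounds than this note shows. Statements on the series, on what has been measured and on what is new or still open speak of the compounds shown alone.

Of the compounds shown here, three sharing one core have been tested in a functional assay on K562 cells (Homo sapiens) for inhibition, read by sulforhodamine B assay, with a stated time of 48 h, tested at 0.01 uM; on this read-out lower numbers stand for a stronger effect and higher numbers for a weaker effect at the one concentration tested. Compound 2 `COc1cc(Cl)cc(-c2nn(-c3cccc(NC(=O)c4cccc(C(F)(F)F)c4)c3)cc2-c2ccncc2)c1` gives 108%. Its number is the highest of the three, yet the gaps to its neighbours lie within the scatter: compound 3 `O=C(Nc1cccc(-n2cc(-c3ccncc3)c(-c3cc(O)cc(Cl)c3)n2)c1)Nc1ccc(Cl)c(Cl)c1` gives 107%, and compound 1 `COc1cc(Cl)cc(-c2nn(-c3cccc(NC(=O)Nc4cccc(C(F)(F)F)c4)c3)cc2-c2ccncc2)c1` gives 104%. Going by the values given here, the one step that differs in a single place, a number 4 percentage points higher from compound 1 to compound 2 (within the scatter), shows that swapping a carbonyl-bound 3-(trifluoromethyl)phenyl for a (3-(trifluoromethyl)phenyl)amino group did not move the read-out beyond the scatter.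

Compound 4 `COc1cc(Cl)cc(-c2nn(-c3cccc(NC(=O)Nc4ccc(Cl)c(Cl)c4)c3)cc2-c2ccncc2)c1` has not yet been measured. It differs from compound 2 by (3,4-dichlorophenyl)amino in place of 3-(trifluoromethyl)phenyl on a carbonyl carbon. This combines the kind of change seen between compound 1 and compound 2 with an exchange of the aromatic substituent pattern; compound 3 carries the same (3,4-dichlorophenyl)amino group on its carbonyl carbon, and its value sits close to those of compound 1 and compound 2. Among the compounds with values here, since the only single-place step available was within the scatter and the dichloro-bearing compound 3 sits in the same narrow band, the expected step is a number 3 percentage points lower from compound 2 to compound 4 (within the scatter), with no movement beyond the scatter in either direction. For compound 4 the estimated value in this assay is 105%, with a range from 95% to 115%.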

Compound 4, a percentage reported as activity, at one concentration (the size of the read-out at that concentration, not a potency): 101%
The estimate for compound 4 lay 4 percentage points above the measured number; measured number inside the range.
By their numbers in this assay, from the lowest: compounds 4, 1, 3 and 2 (each within the scatter of the next).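

In this assay, going by these compounds alone, the new compound gives the first look at the aromatic group alone on the urea: 3,4-dichlorophenyl in place of 3-(trifluoromethyl)phenyl on the amide-type nitrogen gives a number 3 percentage points lower from compound 1 to compound 4 (within the scatter). The exchange of (3,4-dichlorophenyl)amino for 3-(trifluoromethyl)phenyl on the carbonyl carbon gives a number 7 percentage points lower from compound 2 to compound 4 (within the scatter), and a methyl in place of the hydrogen on the oxygen of the aromatic ring gives a number 6 percentage points lower from compound 3 to compound 4 (within the scatter), so neither the group on the carbonyl carbon nor the one on that oxygen has yet shifted the read-out beyond the scatter. Nothing available explains why these exchanges leave the numbers in one narrow band.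

Every number here comes from a single low concentration, and the compounds shown say nothing about how they would behave at higher concentrations, where differences between them might appear. From the compounds shown here alone, it also remains open whether a group of another kind would move the read-out, such as a carboxylic acid or an amine on the aromatic ring of the urea, or a longer chain in place of the methyl on the oxygen.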